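This account rests on a few compounds, and the source may have more. Where it says the series, first, only, none or still open, it means among the compounds named here.

In a functional assay on PC-12 cells (Rattus norvegicus) for cytotoxicity, read by MTT assay, with stated times of 3 h and 2 h, tested at 1 uM (a higher number here means a stronger effect of the compound at the concentration tested, a lower number a weaker effect), three compounds have been measured:

compound 1, `O=C(CCCCC1CCSS1)NCc1cn(CCCOc2ccc3cc(-c4ccc(Br)cc4)c(=O)oc3c2)nn1`, gives 42.8%;
compound 2, `O=C(CCCCC1CCSS1)NCc1cn(CCCOc2ccc3cc(-c4ccc(Cl)cc4)c(=O)oc3c2)nn1`, gives 49.3%;
compound 3, `O=C(CCCCC1CCSS1)NCc1cn(CCCCOc2ccc3cc(-c4ccc(Br)cc4)c(=O)oc3c2)nn1`, gives 37.4%.

Compound 2 differs from compound 1 by one change, (chloro in place of bromo on an aromatic carbon), and the measured step for that change is a number 6.5 percentage points higher from compound 1 to compound 2 (within the scatter). The difference between the two cores of compound 1 and compound 3 is not broken down here; compound 3 stands lowest of the three, and its gap to compound 1 lies within the scatter, while its gap to compound 2 lies beyond it.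

Compound 4, `O=C(CCCCC1CCSS1)NCc1cn(CCCCOc2ccc3cc(-c4ccc(Cl)cc4)c(=O)oc3c2)nn1`, is not yet measured in this assay. It differs from compound 3 by chloro in place of bromo on an aromatic carbon, the same change that turns compound 1 into compound 2, made on an otherwise identical place. On the strength of the step of a number 6.5 percentage points higher from compound 1 to compound 2 (within the scatter), compound 4 is expected to show a step of a number 6.6 percentage points higher from compound 3 to compound 4 (within the scatter) in this assay, a shift of about the same size. The estimate for compound 4 is therefore 44%, with a likely range from 33% to 55%.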

Compound 4, a percentage reported as activity, at one concentration (the size of the read-out at that concentration, not a potency): 46.2%
The estimate for compound 4 lay 2.2 percentage points below the measured number; measured number inside the range.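

In this assay, chloro in place of bromo on an aromatic carbon gives a number 8.8 percentage points higher from compound 3 to compound 4 (within the scatter), and set beside the earlier case the change reads as follows: the same change on two cores in this assay, a number 6.5 percentage points higher (within the scatter) from compound 1 to compound 2 and a number 8.8 percentage points higher (within the scatter) from compound 3 to compound 4, 2.3 percentage points apart, within the scatter of two such steps. The step from bromo to chloro therefore carries from the core of compound 1 to the core of compound 3 with no difference that can be told apart. It does not show that the change has a real effect on either core, since each step stays within the scatter on its own, and two cores cannot speak for any others.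

The compounds shown leave open how fluoro, methoxy or a carboxylic acid in the same place would read. They also leave open whether the step holds on a core with a longer chain.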